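This account rests on a few compounds, and the source may have more. Where it says the series, first, only, none or still open, it means among the compounds named here.

Compounds measured in an assay on Cortex with Norepinephrine transporter (Rattus norvegicus) as the target; on this read-out lower numbers stand for stronger inhibition and higher numbers for weaker inhibition:
compound 1, `CN1CC[C@H](c2ccc(Cl)cc2)[C@@H](CCC(=O)O)C1`, gives 425 nM
compound 2, `COC(=O)/C=C/[C@H]1CN(C)CC[C@@H]1c1ccc(Cl)cc1`, gives 272 nM
compound 3, `CN1CC[C@H](c2ccc(Cl)cc2)[C@@H](CCCO)C1`, gives 564 nM

Compound 3 stands at the highest of the three numbers in this assay. The gap to the nearer number is a 1.3-fold higher number from compound 1 to compound 3 (0.12 log units; within the scatter); the gap to the further number is a 2.1-fold higher number from compound 2 to compound 3 (0.32 log units; beyond the scatter), modest but beyond the scatter. The remaining pair gives a 1.6-fold lower number from compound 1 to compound 2 (0.19 log units; within the scatter).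

The next compound, compound 4, `CN1CC[C@H](c2ccc(Cl)cc2)[C@@H](CCCF)C1`, differs from compound 3 by fluoro in place of hydroxy on a saturated chain carbon, three bonds along the chain from a saturated ring carbon.

Bearing on this step: the change from compound 1 to compound 3 also exchanges the end group of the same chain and stays within the scatter, while the change from compound 2 to compound 3 alters both chain and end group and is only modest. For the measured compounds named here, no measured step exchanges hydroxy for fluoro, so the direct precedent is absent. Across the series, terminal-group exchanges on this chain have moved this assay little, so the expected step for compound 4 is a 1.1-fold lower number from compound 3 to compound 4 (0.05 log units; within the scatter), not beyond the scatter in either direction. Compound 4 is therefore estimated at 500 nM, with a range of 220 nM to 1200 nM.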

Compound 4, inhibition constant: 356 nM
Estimate against measurement, compound 4: 1.4-fold (0.15 log units) above, and the stated range covers the measured number.
By their numbers in this assay, from the lowest: compounds 2, 4, 1 and 3 (each within the scatter of the next, the first and the last beyond it).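

In this assay, for the compounds shown here, the first direct exchange of the chain-end group gives a 1.6-fold lower number from compound 3 to compound 4 (0.20 log units; within the scatter): fluoro carries no hydrogen-bond donor or acceptor where hydroxy carries both, and the number stays within the scatter. The 3-fluoropropyl chain of compound 4 also lies within the scatter of the other two chains, with a 1.3-fold higher number from compound 2 to compound 4 (0.12 log units; within the scatter) and a 1.2-fold lower number from compound 1 to compound 4 (0.08 log units; within the scatter), even though compound 2 and compound 3 stand apart beyond it. No measured property of these groups accompanies the numbers, so the result offers no explanation of them.

The compounds shown leave open whether an amine at the end of the chain would also stay within the scatter. They also leave open whether a longer chain, such as 4-fluorobutyl, would do so.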